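The source may hold more compounds than are shown below. What is called first, only, known or untested is meant among the compounds shown, and "the series" means these compounds.

The measured compounds:
compound 1, `Cc1cc(Nc2nc(NCc3cccc(F)c3)nc3[nH]ncc23)n[nH]1`, in an assay on isolated protein for inhibition of serine/threonine-protein kinase PAK 4 (Homo sapiens), read by HTRF, with a stated time of 60 min; a higher number here means a weaker inhibitor, a lower number a stronger inhibitor: 458 nM
compound 2, `Cc1cc(Nc2nc(NCc3cccc(Cl)c3)nc3[nH]ncc23)n[nH]1`: 611 nM
compound 3, `Cc1cc(Nc2nc(NCc3ccc(F)cc3)nc3[nH]ncc23)n[nH]1`: 395 nM

Compound 4, `Cc1cc(Nc2nc(NCc3ccc(Cl)cc3)nc3[nH]ncc23)n[nH]1`, has not yet been measured in this assay. Compounds 1 and 3 are built from the same atoms joined differently: 4-fluorophenyl in place of 3-fluorophenyl on a saturated chain carbon bound to a nitrogen on an aromatic ring. From compound 1 to compound 2 the change is chloro in place of fluoro on an aromatic carbon, and it gave a 1.3-fold higher number from compound 1 to compound 2 (0.13 log units; within the scatter). Compound 4 carries the same kind of change relative to compound 3, (chloro in place of fluoro on an aromatic carbon); here the place is para to a large group, whereas between compound 1 and compound 2 it is meta to a large group. Because a 1.3-fold higher number from compound 1 to compound 2 (0.13 log units; within the scatter) stayed within the scatter, the expected step is a 1.3-fold higher number from compound 3 to compound 4 (0.12 log units; within the scatter). Compound 4 is accordingly estimated at 520 nM.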

Compound 4, half-maximal inhibitory concentration: 515 nM
Estimate against measurement, compound 4: 1.0-fold (0.00 log units) above, within the range that was stated.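

In this assay, chloro in place of fluoro gave a 1.3-fold higher number from compound 3 to compound 4 (0.12 log units; within the scatter), and this step agrees with the one seen earlier at the other place on the ring: the same change on two cores in this assay, a 1.3-fold higher number (0.13 log units; within the scatter) from compound 1 to compound 2 and a 1.3-fold higher number (0.12 log units; within the scatter) from compound 3 to compound 4, 1.0-fold (0.01 log units) apart, within the scatter of two such steps The remaining new steps, a 1.2-fold lower number from compound 2 to compound 4 (0.07 log units; within the scatter) and a 1.1-fold higher number from compound 1 to compound 4 (0.05 log units; within the scatter), also lie within the scatter. This shows that the change carried over between these two closely related compound pairs, but as a step too small to read, so it shows neither a real difference between chloro and fluoro nor that the agreement would hold on a different core.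

The compounds shown leave open whether a methoxy group or an amine on this ring, or a longer chain in place of the benzyl group, would give a step beyond the scatter.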